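This account rests on a few compounds, and the source may have more. Where it says the series, first, only, none or still open, it means among the compounds named here.

Compound 3 `COc1ccc(/C=C2\S/C(=N\c3nc(-c4c(C)n(C)n(-c5ccccc5)c4=O)cs3)N(c3ccccc3)C2=O)cc1` is the only one of the three measured compounds with a number rather than a limit: in a functional assay on MCF7 cells (Homo sapiens) for cytotoxicity, read by sulforhodamine B assay, with a stated time of 72 h (on this read-out higher numbers stand for weaker inhibition and lower numbers for stronger inhibition), compound 3 gives 26100 nM. Compound 1 `Cc1c(-c2csc(/N=C3\S/C(=C\c4ccccc4)C(=O)N3c3ccccc3)n2)c(=O)n(-c2ccccc2)n1C` reaches only the limit, giving > 100000 nM in this assay. Compound 2 `Cc1c(-c2csc(/N=C3\S/C(=C\c4ccc(N(C)C)cc4)C(=O)N3c3ccccc3)n2)c(=O)n(-c2ccccc2)n1C` likewise reaches only the limit, giving > 100000 nM in this assay. Compound 4 `Cc1ccc(/C=C2\S/C(=N\c3nc(-c4c(C)n(C)n(-c5ccccc5)c4=O)cs3)N(c3ccccc3)C2=O)cc1` differs from compound 3 in one place: methyl in place of methoxy on an aromatic carbon. The steps bearing on it run the other way, hydrogen to methoxy, giving an at least 3.8-fold lower number from compound 1 to compound 3 (0.58 log units; beyond the scatter), and dimethylamino to methoxy, giving an at least 3.8-fold lower number from compound 2 to compound 3 (0.58 log units; beyond the scatter); both single out the methoxy group as what separates compound 3 from the limit-bound compounds. Removing it in favour of methyl is therefore expected to raise the number, a 2.3-fold higher number from compound 3 to compound 4 (0.36 log units; beyond the scatter). Compound 4 is estimated at about 60000 nM, within 20000 nM to 150000 nM.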

Compound 4, half-maximal inhibitory concentration: > 100000 nM
Compound 4 was reported as a limit; the forecaster's own chance of this, stated with the estimate: 40%; middle value at least 1.6-fold (0.22 log units) away from the limit.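

Methyl in place of methoxy on this aromatic carbon, para to a large group, gives an at least 3.8-fold higher number from compound 3 to compound 4 (0.58 log units; beyond the scatter), so methyl does not keep the number that methoxy gives. Compound 4 returns only a limit, not a number: the limit of > 100000 nM in this assay, at which 3 of the 4 values shown sit. Methoxy is thus the only one of the four groups shown here that gives a number, and the steps to compound 4 from compound 1 and from compound 2 join two limits and cannot be read.

As far as these compounds go, it stays open whether the oxygen is what counts, which a hydroxyl, ethoxy or chlorine in this place would address. From the compounds shown here alone, how far compound 1, compound 2 and compound 4 differ from one another also remains unknown.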